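The compounds below may be only part of what the source reports. "The series", "measured", "known", "first", "only" and "open" are said of these compounds alone.

Compound 3 `N#Cc1cc(F)cc(C(=O)Nc2cccc(C(F)(F)F)c2)c1` has, in an in vitro functional assay on HEK293-A cells for antagonist activity at metabotropic glutamate receptor 5 (Rattus norvegicus), read by calcium flux (on this read-out higher numbers stand for weaker inhibition and lower numbers for stronger inhibition), the lowest of the two numbers shown, giving 543 nM. Compound 1 `N#Cc1cc(F)cc(C(=O)Nc2ccccn2)c1` gives 3010 nM in this assay. Compound 2 `Cn1ccc(NC(=O)c2cc(F)cc(C#N)c2)n1` reaches only the limit of the assay, > 10000 nM, so its result is a limit rather than a number. Within the data shown here, the step of an at least 3.3-fold higher number from compound 1 to compound 2 (0.52 log units; beyond the scatter) is the only measured change at a single place, and it concerns a different group of the molecule from the change now considered. Compound 4 `CS(=O)(=O)c1cccc(NC(=O)c2cc(F)cc(C#N)c2)c1` differs from compound 3 by methylsulfonyl in place of trifluoromethyl on an aromatic carbon. Among the measured compounds shown here, no measured step covers this exchange, so the expectation rests on where compound 3 stands alone. Compound 4 is expected to give 3000 nM, within a range from 700 nM to 10000 nM. The estimated step is a 5.5-fold higher number from compound 3 to compound 4 (0.74 log units; beyond the scatter), toward weaker inhibition.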

Compound 4, half-maximal inhibitory concentration: > 30000 nM
Compound 4 gave a limit, no number (the forecaster's own chance of this, stated with the estimate: 30%); middle value at least 10-fold (1.00 log units) away from the limit.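

The place on the aromatic ring that holds trifluoromethyl in compound 3 proves highly sensitive: the exchange for methylsulfonyl gives an at least 55-fold higher number from compound 3 to compound 4 (1.74 log units; beyond the scatter) in this assay and so much weaker inhibition. Methylsulfonyl has as many heavy atoms as trifluoromethyl but, unlike it, carries hydrogen-bond acceptors. Compound 4 gives a limit, not a number: the limit of > 30000 nM in this assay, at which 1 of the 4 values shown sits.

Whether those acceptors account for the loss stays open. So does how an amine, a carboxylic acid or a simple methyl group would fare at this place.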